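Compound 1 to compound 3: 4-bromophenyl for 2-methylphenyl

The compounds below may be only part of what the source reports. "The series", "measured", "known", "first", "only" and "open" are said of these compounds alone.

For the measured compounds named here, in a functional assay on MGC-803 cells (Homo sapiens) for antiproliferative activity, read by MTT assay, with a stated time of 72 h (a lower number here means a stronger inhibitor, a higher number a weaker inhibitor), compound 1 `Cc1ccccc1-n1nc(-c2ccccc2)nc1CNc1ccc(C(=O)NO)cc1` gives 12300 nM as the higher of the two numbers so far. Compound 2 `O=C(NO)c1ccc(NCc2nc(-c3ccc(Cl)cc3)nn2-c2ccccc2)cc1` gives 5970 nM and lies below it, beyond the scatter. Compound 3 `O=C(NO)c1ccc(NCc2nc(-c3ccccc3)nn2-c2ccc(Br)cc2)cc1` differs from compound 1 in one place (4-bromophenyl in place of 2-methylphenyl on an aromatic nitrogen) with 4-bromophenyl in place of 2-methylphenyl on an aromatic nitrogen. Going by the values given here, no measured step isolates this change, so only a modest fall in this assay is expected, the estimated step being a 1.9-fold lower number from compound 1 to compound 3 (0.28 log units; within the scatter) in size. For compound 3 the expected value is 6500 nM with 2200 nM to 17000 nM as the estimated range.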

Compound 3, half-maximal inhibitory concentration: 9300 nM
Beside the measured number, compound 3's estimate is 1.4-fold (0.16 log units) below it; measured number inside the range.
By their numbers in this assay, from the lowest: compounds 2, 3 and 1 (each within the scatter of the next, the first and the last beyond it).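

On the aromatic nitrogen, the change to 4-bromophenyl from 2-methylphenyl gives a 1.3-fold lower number from compound 1 to compound 3 (0.12 log units; within the scatter) in this assay, the first step read at this position. The two groups are therefore not told apart here, and the position carries either one without a difference beyond the scatter. No measured property bears on this result.

The step alters both the substituent and its location on the phenyl group, and the compounds shown do not separate the two. Open too, from the compounds shown here alone, is whether a phenyl group bearing an amine or a carboxylic acid on this nitrogen would shift the number beyond the scatter.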